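A few compounds are considered here, and "the series" means these few. Any claim that something is new, unique, unknown or untested is made for them only; others in the source may bear on it.

Of the compounds shown here, three have so far been measured in an assay on tissue (HeLa cells) for inhibition of Indoleamine 2,3-dioxygenase 1 (Homo sapiens), read by fluorescence, with a stated time of 18 h; on this read-out higher numbers stand for weaker inhibition and lower numbers for stronger inhibition. Compound 1 `CCC(c1nc2ncc(Cl)cc2[nH]1)[C@H]1CC[C@@H](c2ccnc3ccc(C(F)(F)F)cc32)CC1` gives 2 nM in this assay. Compound 3 `CCC(c1nc2ncc(Cl)cc2[nH]1)[C@H]1CC[C@@H](c2ccnc3ccc(F)cc32)CC1` shares the core of compound 1 and differs from it in one place: fluoro in place of trifluoromethyl on an aromatic carbon. In this assay compound 3 gives 2 nM, and the step is no change at the digits printed from compound 1 to compound 3 (within the scatter). Compound 2 `CCC(Nc1nnc(-c2ccc(OC)cc2)o1)[C@H]1CC[C@@H](c2ccnc3ccc(C(F)(F)F)cc32)CC1` is built on a different core; the difference between the two cores is not broken down here. In this assay compound 2 gives 3 nM, a number that sits within the scatter of those of compound 1 and compound 3, so the three cannot be ranked against one another on this read-out.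

Compound 4 `CCC(Nc1nnc(-c2ccc(OC)cc2)o1)[C@H]1CC[C@@H](c2ccnc3ccc(F)cc32)CC1` has not yet been measured. It differs from compound 2 in one place: fluoro in place of trifluoromethyl on an aromatic carbon. This is the same change, at the same place, that separates compound 1 from compound 3; among the compounds shown it occurs twice in all. The single measured example of it produced no movement, and nothing shown suggests that the core of compound 2 should answer the change differently. For compound 4 the expected step is therefore no change at the digits printed from compound 2 to compound 4 (within the scatter), because no change at the digits printed from compound 1 to compound 3 (within the scatter). The estimate for compound 4 in this assay is 3 nM, with a likely range from 1.5 nM to 7 nM.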

Compound 4, half-maximal inhibitory concentration: 6 nM
Compound 4: the middle estimate sits 2.0-fold (0.30 log units) below what was measured, within the range that was stated.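

For the compounds shown here, replacing trifluoromethyl with fluoro on the core of compound 2 gives, in this assay, a 2.0-fold higher number from compound 2 to compound 4 (0.30 log units; within the scatter), so this swap again produces no step that stands clear of ordinary repeat-to-repeat variation. Set beside the earlier example, the swap gives the same reading on both cores, with no difference between them that can be told apart: the same change on two cores in this assay, no change at the digits printed (within the scatter) from compound 1 to compound 3 and a 2.0-fold higher number (0.30 log units; within the scatter) from compound 2 to compound 4, 2.0-fold (0.30 log units) apart, within the scatter of two such steps. This shows only that, for these two matched pairs, the result on one core was a fair guide to the result on the other; it does not show that the two cores answer the change identically, since a small real difference could hide within the scatter, and two pairs cannot establish a rule for the whole series.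

The compounds shown carry only trifluoromethyl or fluoro on this aromatic carbon, so it stays open what a plain hydrogen, a chlorine, a methoxy group, a nitrile or an amine would do there. From the compounds shown here alone, it also stays open whether the swap would read the same way on a third core, or on a core where the starting compound gives a much higher number than those seen here.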